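The source may hold more compounds than are shown below. What is called first, only, known or untested is meant among the compounds shown, and "the series" means these compounds.

Three compounds share one core and differ only in the aryl group attached to a carbonyl carbon. Compound 1 `COc1ccc(C(=O)ON=C2CC(c3ccc(O)c(OC)c3)N(C)C(c3ccc(O)c(OC)c3)C2)c(OC)c1` carries a 2,4-dimethoxyphenyl there, and in a functional assay, read by spectrophotometry, with a stated time of 30 min (on this read-out higher numbers stand for weaker inhibition and lower numbers for stronger inhibition), compound 1 gives 41000 nM. Compound 2 `COc1cc(C2CC(=NOC(=O)c3cccc(O)c3)CC(c3ccc(O)c(OC)c3)N2C)ccc1O` carries a 3-hydroxyphenyl, and in this assay compound 2 gives 16500 nM, so that a 2.5-fold lower number from compound 1 to compound 2 (0.40 log units; beyond the scatter). Compound 3 `COc1cc(C2CC(=NOC(=O)c3ccc([N+](=O)[O-])cc3)CC(c3ccc(O)c(OC)c3)N2C)ccc1O` carries a 4-nitrophenyl, and in this assay compound 3 gives 79000 nM, the highest of the three numbers, with a 1.9-fold higher number from compound 1 to compound 3 (0.28 log units; within the scatter) and a 4.8-fold higher number from compound 2 to compound 3 (0.68 log units; beyond the scatter).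

Compound 4 `COc1cc(C2CC(=NOC(=O)c3ccc(Br)cc3)CC(c3ccc(O)c(OC)c3)N2C)ccc1O` differs from compound 3 in one place: bromo in place of nitro on an aromatic carbon. Within the data shown here, none of the measured steps exchanges one substituent for another on this ring while keeping the rest of it; all three swap the whole aryl group, and they moved the number by modest amounts in both directions. A change confined to one position of that aryl group is therefore expected to shift the number modestly at most, with the direction left open by the data. Compound 4 is expected to show a 1.8-fold lower number from compound 3 to compound 4 (0.24 log units; within the scatter). Compound 4 is estimated at about 45000 nM, within a range from 15000 nM to 130000 nM.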

Compound 4, half-maximal inhibitory concentration: 108000 nM
Beside the measured number, compound 4's estimate is 2.4-fold (0.38 log units) below it; measured number inside the range.
By their numbers in this assay, from the lowest: compound 2; then compounds 1, 3 and 4 (each within the scatter of the next, the first and the last beyond it).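

Among these compounds, the step from nitro to bromo is the first exchange of one substituent for another on this aromatic carbon with the rest of the ring kept. In this assay it gives a 1.4-fold higher number from compound 3 to compound 4 (0.14 log units; within the scatter), so the number does not separate these two groups, although they differ in their atoms and in hydrogen-bond acceptors. The 4-bromophenyl ester also stays well apart from the 3-hydroxyphenyl one, with a 6.5-fold higher number from compound 2 to compound 4 (0.82 log units; beyond the scatter), and it shows a 2.6-fold higher number from compound 1 to compound 4 (0.42 log units; beyond the scatter), a gap from the 2,4-dimethoxyphenyl ester that lies beyond the scatter, whereas the step from that ester to the 4-nitrophenyl one lay within it. No measurement is available that would explain these numbers.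

The compounds shown leave open whether an amine or a carboxylic acid on this same aromatic carbon would stay level with nitro and bromo or come closer to compound 2 at 16500 nM. They also do not settle whether the lower number of compound 2 goes with the hydroxy group itself or with its place in the 3-hydroxyphenyl, which a 4-hydroxyphenyl would test.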